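Chain-length series and a ring-amine replacement

This account rests on a few compounds, and the source may have more. Where it says the series, first, only, none or still open, it means among the compounds named here.

Compound 1 `CN(C)CCCCCCCOc1ccc2oc(-c3ccccc3)cc(=O)c2c1`, compound 2 `CN(C)CCCCCCCCOc1ccc2oc(-c3ccccc3)cc(=O)c2c1` and compound 3 `CN(C)CCCCCCCCCOc1ccc2oc(-c3ccccc3)cc(=O)c2c1` share one core and differ only in chain length. In an assay on isolated protein (Cavia porcellus) with Sigma non-opioid intracellular receptor 1 (Homo sapiens) as the target, read by radioligand binding (on this read-out lower numbers stand for stronger inhibition and higher numbers for weaker inhibition), compound 1 gives 188 nM, compound 2 gives 143 nM and compound 3 gives 202 nM; the steps of a 1.3-fold lower number from compound 1 to compound 2 (0.12 log units; within the scatter), a 1.1-fold higher number from compound 1 to compound 3 (0.03 log units; within the scatter) and a 1.4-fold higher number from compound 2 to compound 3 (0.15 log units; within the scatter) all lie within the scatter, so compound 3 sits level with the other two. Compound 4 `O=c1cc(-c2ccccc2)oc2ccc(OCCCN3CCC(O)CC3)cc12` changes more: 4-hydroxypiperidin-1-yl in place of 6-(dimethylamino)hexyl on a saturated chain carbon, three bonds along the chain from an oxygen on an aromatic ring. Within the data shown here, no measured step covers this swap of a ring for the open chain, so the chain-length steps give little guidance and the expectation is wide. Compound 4 is expected near 350 nM, within 90 nM to 1400 nM. The expected step is a 1.7-fold higher number from compound 3 to compound 4 (0.24 log units; within the scatter), with no direction called.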

Compound 4, half-maximal inhibitory concentration: 123 nM
For compound 4 the middle estimate is 2.8-fold (0.45 log units) above the measured one; measured number inside the range.
By their numbers in this assay, from the lowest: compounds 4, 2, 1 and 3 (each within the scatter of the next).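

In this assay, 4-hydroxypiperidin-1-yl in place of the open dimethylamino chains, on a saturated chain carbon three bonds along the chain from an oxygen on an aromatic ring, leaves the read-out level: a 1.6-fold lower number from compound 3 to compound 4 (0.22 log units; within the scatter) and a 1.2-fold lower number from compound 2 to compound 4 (0.07 log units; within the scatter) and a 1.5-fold lower number from compound 1 to compound 4 (0.18 log units; within the scatter) all stay small. This position therefore accepts a ring bearing a hydroxyl, with its hydrogen-bond donor, as readily as the open chains of compound 1, compound 2 and compound 3. Nothing available explains why these groups read alike.

Open, as far as these compounds go, is whether the hydroxyl matters, which plain piperidin-1-yl or morpholin-4-yl at the same place would test. Also open, from the compounds shown here alone, is whether 4-hydroxypiperidin-1-yl holds this level on a longer chain.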